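Aromatic substituent swap on compound 1: bromo analogue estimate

The source may hold more compounds than are shown below. What is called first, only, known or untested is meant among the compounds shown, and "the series" means these compounds.

Measured so far:
compound 1 `COc1ccc(-c2noc(CN3N=N[C@@H]4C(=O)N(c5ccccc5)C(=O)[C@@H]43)n2)cc1`, > 100 ug/mL
compound 2 `O=C1[C@H]2N=NN(Cc3nc(-c4ccc(Cl)cc4)no3)[C@H]2C(=O)N1c1ccccc1`, 49.5 ug/mL
compound 3 `O=C1[C@H]2N=NN(Cc3nc(-c4ccc(C(F)(F)F)cc4)no3)[C@H]2C(=O)N1c1ccccc1`, 44.4 ug/mL

In an ADME assay on L6 cells (Rattus norvegicus) for cytotoxicity, read by resazurin assay, with a stated time of 72 h (on this read-out lower numbers stand for stronger inhibition and higher numbers for weaker inhibition), compound 1 gives > 100 ug/mL, which is a limit of the assay and not a number (the limit of > 100 ug/mL in this assay, at which 1 of the 3 values shown sits). Compound 2 gives 49.5 ug/mL and compound 3 gives 44.4 ug/mL; the two sit within the scatter of each other, as a 1.1-fold lower number from compound 2 to compound 3 (0.05 log units; within the scatter) shows.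

Compound 4 `O=C1[C@H]2N=NN(Cc3nc(-c4ccc(Br)cc4)no3)[C@H]2C(=O)N1c1ccccc1` differs from compound 1 by bromo in place of methoxy on an aromatic carbon. Within the data shown here, the steps that bear on this change are an at least 2.0-fold lower number from compound 1 to compound 2 (0.30 log units; that floor lies within the scatter) and an at least 2.2-fold lower number from compound 1 to compound 3 (0.35 log units; beyond the scatter), each also replacing methoxy on an aromatic carbon. Because compound 1 stands at the limit (the limit of > 100 ug/mL in this assay, at which 1 of the 3 values shown sits), only a floor for those steps is known, yet both point the same way, towards a lower number. The bromo change is therefore expected to give a step of similar size and direction, with no basis in the series for a difference from chloro or trifluoromethyl.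

Compound 4 is expected to give 48 ug/mL, between 24 ug/mL and 100 ug/mL. This corresponds to the expected step of an at least 2.0-fold lower number from compound 1 to compound 4 (0.31 log units; beyond the scatter).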

Compound 4, half-maximal inhibitory concentration: 58.6 ug/mL
For compound 4 the middle estimate is 1.2-fold (0.09 log units) below the measured one, within the range that was stated.
By their numbers in this assay, from the lowest: compounds 3, 2 and 4 (each within the scatter of the next). At a limit, above all of these: compound 1.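

In this assay, bromo joins chloro and trifluoromethyl at this position without separating from either: a 1.2-fold higher number from compound 2 to compound 4 (0.07 log units; within the scatter) and a 1.3-fold higher number from compound 3 to compound 4 (0.12 log units; within the scatter). Across these three groups, the substituent on the aromatic carbon para to a large group therefore makes no readable difference to the value. The move from 4-methoxyphenyl to 4-bromophenyl gives an at least 1.7-fold lower number from compound 1 to compound 4 (0.23 log units; that floor lies within the scatter), a floor that adds a third step in the same direction but cannot fix its size, and the entry for compound 1 is a limit of the assay and not a number: the limit of > 100 ug/mL in this assay, at which 1 of the 4 values shown sits.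

From the compounds shown here alone, whether this level holds for a very different group at this position, such as an amine, a carboxylic acid or a longer chain, stays open. Also open, going by these compounds, is how far the methoxy compound really lies from the other three, since only a floor is available for each of those steps.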